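A few compounds are considered here, and "the series" means these few. Any claim that something is new, unique, unknown or untested is made for them only; others in the source may bear on it.

Measured so far:
compound 1 `O=C(CSc1nc(Nc2ccccc2)c2ccccc2n1)Nc1ccccc1Br`: 14100 nM
compound 2 `CCc1cccc(NC(=O)CSc2nc(Nc3ccccc3)c3ccccc3n2)c1`: 12400 nM
compound 3 `O=C(CSc1nc(Nc2ccccc2)c2ccccc2n1)Nc1ccc([N+](=O)[O-])cc1`: 16800 nM

In a functional assay on MDA-MB-231 cells (Homo sapiens) for inhibition, read by MTT assay, with a stated time of 72 h (on this read-out higher numbers stand for weaker inhibition and lower numbers for stronger inhibition), compound 2 stands at the lowest of the three numbers, but compound 1 and compound 3 lie within the scatter of it, so the three cannot be ordered. Compound 4 `O=C(CSc1nc(Nc2ccccc2)c2ccccc2n1)Nc1ccc(Cl)c(Cl)c1` differs from compound 2 in one place: 3,4-dichlorophenyl in place of 3-ethylphenyl on an amide-type nitrogen. Every measured step in this series also swaps the group on the amide-type nitrogen, and each of them stayed within the scatter: a 1.1-fold lower number from compound 1 to compound 2 (0.06 log units; within the scatter), a 1.2-fold higher number from compound 1 to compound 3 (0.08 log units; within the scatter), a 1.4-fold higher number from compound 2 to compound 3 (0.13 log units; within the scatter). Nothing in these steps points to a move beyond the scatter for another aryl group at that position, though none of them carries two chlorines. Compound 4 is therefore expected to sit close to compound 2, with a 1.0-fold higher number from compound 2 to compound 4 (0.02 log units; within the scatter) as the expected step. The estimate for compound 4 in this assay is 13000 nM, expected to fall between 7000 nM and 25000 nM.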

Compound 4, half-maximal inhibitory concentration: 14500 nM
Compound 4: middle estimate off by 1.1-fold (0.05 log units), on the low side; the measured number falls inside the stated range.
By their numbers in this assay, from the lowest: compounds 2, 1, 4 and 3 (each within the scatter of the next).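

Two chlorines on the aryl group on the amide-type nitrogen still leave this assay within the scatter of every earlier compound (a 1.2-fold higher number from compound 2 to compound 4 (0.07 log units; within the scatter)), (a 1.2-fold lower number from compound 3 to compound 4 (0.06 log units; within the scatter)) and (a 1.0-fold higher number from compound 1 to compound 4 (0.01 log units; within the scatter)). Across the four aryl groups shown, 3,4-dichlorophenyl included, no swap at this position gives a step beyond the scatter, and no compound goes against this. No measurement is available that bears on the reason for this.

Still open, as far as these compounds go, is whether a carboxylic acid or an amine on that aryl group, or a longer chain in its place, would move the number beyond the scatter. Changes to the shared core also remain open.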